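Alkyl Chain Extension on a Sulfonium Alpha-Glucosidase Inhibitor

A few compounds are considered here, and "the series" means these few. Any claim that something is new, unique, unknown or untested is made for them only; others in the source may bear on it.

Measured compounds:
- compound 1 `CO[C@@H](CO)[C@H](O)C[S+]1C[C@@H](O)[C@H](O)[C@H]1CO`: 2000 nM
- compound 2 `CCCCCO[C@@H](CO)[C@H](O)C[S+]1C[C@@H](O)[C@H](O)[C@H]1CO`: 1500 nM

In an assay for inhibition of Maltase-glucoamylase (Homo sapiens), using microsomes, with a stated time of 30 min (on this read-out higher numbers stand for weaker inhibition and lower numbers for stronger inhibition), compound 1 gives 2000 nM, the highest of the two numbers shown, with compound 2 standing nearest at 1500 nM. Compound 3 `CC(C)(C)CO[C@@H](CO)[C@H](O)C[S+]1C[C@@H](O)[C@H](O)[C@H]1CO` has not yet been measured. It differs from compound 1 by tert-butyl in place of hydrogen on a saturated chain carbon bound to an oxygen on a saturated carbon. Among the measured compounds shown here, the one measured step that bears on this is a 1.3-fold lower number from compound 1 to compound 2 (0.12 log units; within the scatter), where a longer saturated chain was attached at the same position; that change stayed within the scatter. For the measured compounds named here, the change to compound 3 is of the same kind, a saturated carbon group added at the same place, and no measured pair suggests that branching rather than a straight chain behaves differently. For compound 3 the expected step is therefore a 1.3-fold lower number from compound 1 to compound 3 (0.10 log units; within the scatter), meaning no shift beyond the scatter in this assay. Compound 3 is estimated at 1600 nM, with a range from 600 nM to 4500 nM.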

Compound 3, half-maximal inhibitory concentration: 470 nM
Compound 3: the middle estimate sits 3.4-fold (0.53 log units) above what was measured; measured number outside the range, below it.
By their numbers in this assay, from the lowest: compound 3; then compounds 2 and 1 (each within the scatter of the next).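

In this assay, this saturated chain carbon bound to an oxygen turns out to be sensitive to which carbon group is added, since tert-butyl gives a 4.3-fold lower number from compound 1 to compound 3 (0.63 log units; beyond the scatter), whereas the butyl step to compound 2 stayed within the scatter. The direct comparison, a 3.2-fold lower number from compound 2 to compound 3 (0.50 log units; beyond the scatter), shows that the branched tert-butyl and the straight butyl are not interchangeable at this place, a distinction that compound 1 and compound 2 alone could not reveal. No supporting data here account for this difference.

On these data alone, it remains open whether a smaller branched group such as isopropyl, a ring such as cyclohexyl, or a chain ending in an amine would give a number like that of compound 3. As far as these compounds go, it is also open whether the tert-butyl step would hold against other enzymes.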